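Lengthening the Chain of Compound 2 Once More

The source may hold more compounds than are shown below. What is called first, only, known or untested is meant among the compounds shown, and "the series" means these compounds.

In a functional assay on brain (Rattus norvegicus, strain Wistar) for inhibition (a higher number here means a weaker inhibitor, a lower number a stronger inhibitor), compound 1 (`CCCCCCc1ccc(-c2c(C)[nH]c(=O)n2C2CCCCC2)cc1`) gives 13700 nM and compound 2 (`CCCCCCCCc1ccc(-c2c(C)[nH]c(=O)n2C2CCCCC2)cc1`) gives 10300 nM. Going by the values given here, compound 2 therefore stands level with compound 1, the only other measured compound, as the two values lie within the usual scatter of each other. Compound 3 (`CCCCCCCCCCc1ccc(-c2c(C)[nH]c(=O)n2C2CCCCC2)cc1`) keeps the shared core and differs from compound 2 by ethyl in place of hydrogen on a saturated chain carbon, eight bonds along the chain from an aromatic carbon. The added ethyl lengthens the same chain, with the replaced hydrogen now on a saturated chain carbon eight bonds along the chain from an aromatic carbon.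

Among the compounds with values here, only one measured step bears on this change: the same replacement made six bonds along the chain, a 1.3-fold lower number from compound 1 to compound 2 (0.12 log units; within the scatter). That step stays within the scatter, and a single step establishes no trend. A similar outcome is therefore expected in this assay, with no shift in either direction beyond the scatter. The expected step is a 1.1-fold lower number from compound 2 to compound 3 (0.04 log units; within the scatter). For compound 3 the estimated value is 9500 nM, with an expected range of 4000 nM to 22000 nM.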

Compound 3, half-maximal inhibitory concentration: 27000 nM
Compound 3: the middle estimate sits 2.8-fold (0.45 log units) below what was measured; the measured number lies above the stated range.
By their numbers in this assay, from the lowest: compounds 2, 1 and 3 (each within the scatter of the next, the first and the last beyond it).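

In this assay, the replacement eight bonds along the chain from an aromatic carbon gives a 2.6-fold higher number from compound 2 to compound 3 (0.42 log units; beyond the scatter) and so, unlike the earlier step six bonds along, moves the number beyond the scatter, though only modestly and towards weaker inhibition. Lengthening this chain is therefore not neutral throughout: with these compounds, the added ethyl has a readable effect at the outer position, but not at the inner one. Measured against the shorter chain of compound 1, however, butyl in place of hydrogen six bonds along the chain gives a 2.0-fold higher number from compound 1 to compound 3 (0.29 log units; within the scatter) and stays within the scatter, so the change across the whole series is small, and nothing shown accounts for the step seen at compound 3.

Three chain lengths cannot show whether the higher number at compound 3 marks the start of a continuing rise or is a single modest step, and a longer chain such as dodecyl or a shorter one such as propyl would bear on that. Also open, on these data alone, is how a chain ending in an amine or a carboxylic acid would fare at this position.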